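A Sulfur-Bearing Chain in Place of the Methyl

A few compounds are considered here, and "the series" means these few. Any claim that something is new, unique, unknown or untested is made for them only; others in the source may bear on it.

Compound 2, with the structure `CCn1c(=N)sc2cc(OC(F)(F)F)ccc21`, was tested in a functional assay on the whole organism with Rattus norvegicus as the target (on this read-out lower numbers stand for an effect already at smaller amounts and higher numbers for an effect only at larger amounts of compound), and gave 5 mg/kg. Among the measured compounds shown here, the only other compound measured in this assay is compound 1, with the structure `CCCCCc1ccc2nc(N)sc2c1`, which in this assay gave 7.5 mg/kg; compound 2 holds the lower of the two numbers, but the gap between them lies within the usual scatter, so the two values show no difference that can be relied on. The untested compound 3, with the structure `C[S+]([O-])Cn1c(=N)sc2cc(OC(F)(F)F)ccc21`, differs from compound 2 in one place: a group of 3 heavy atoms (1 carbon, 1 oxygen, 1 sulfur; no ring) in place of one carbon atom, on a saturated chain carbon bound to an aromatic nitrogen. For the measured compounds named here, no step between two measured compounds is on record to guide the size of this change, so the expectation rests on compound 2 alone. Compound 3 is expected to give about 8 mg/kg, with a plausible range from 3 mg/kg to 20 mg/kg. The step from compound 2 to compound 3 is estimated as a 1.6-fold higher number from compound 2 to compound 3 (0.20 log units; within the scatter), a move toward the higher end that may not exceed the scatter.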

Compound 3, dose for half-maximal effect: 2.3 mg/kg
Estimate against measurement, compound 3: 3.5-fold (0.54 log units) above; the measured number lies below the stated range.
By their numbers in this assay, from the lowest: compound 3; then compounds 2 and 1 (each within the scatter of the next).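

At the saturated chain carbon bound to an aromatic nitrogen, the methyl can give way to a larger sulfur-bearing group without loss: in this assay the change gives a 2.2-fold lower number from compound 2 to compound 3 (0.34 log units; beyond the scatter) and so makes a modest step that stands clear of the usual variation. Among the compounds shown here, this is the first reliable difference, as the values of the two earlier compounds could not be told apart. No measurement on hand accounts for the step, so it stands as an observation without a stated cause.

On these data alone, the change adds sulfur, oxygen and length together, so the part of the new group that carries the step remains open. A plain thioether chain, a sulfone or a longer alkyl chain at this place would begin to separate these contributions.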